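Replacing an anilide with a piperidine amide

The source may hold more compounds than are shown below. What is called first, only, known or untested is meant among the compounds shown, and "the series" means these compounds.

Compound 2 `CN1C[C@H](C(=O)Nc2ccc(Cl)c(Cl)c2)[C@@H](c2ccc(/C=C/C(=O)Nc3ccccc3N)cc2)C1` and compound 1 `CN1C[C@H](C(=O)Nc2ccc(C3CC3)cc2)[C@@H](c2ccc(/C=C/C(=O)Nc3ccccc3N)cc2)C1` share a core and differ only in the group on the amide-type nitrogen. In an in vitro ADME assay on microsomes from liver (Mus musculus) for pharmacokinetics, read by LC-MS, with a stated time of 10 min, tested at 1 uM (a lower number here means slower removal, a higher number faster removal of the compound), compound 1 gives 60 mL/min/kg, while compound 2 gives 36 mL/min/kg. Within the data shown here, the only step between them is a 1.7-fold lower number from compound 1 to compound 2 (0.22 log units; within the scatter), so compound 2 holds the lowest of the two numbers, but its gap to compound 1 is within the scatter and no order can be read from it.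

Compound 3 `CN1C[C@H](C(=O)N2CCCCC2)[C@@H](c2ccc(/C=C/C(=O)Nc3ccccc3N)cc2)C1` departs from compound 2 by piperidin-1-yl in place of (3,4-dichlorophenyl)amino on a carbonyl carbon. This exchange removes the hydrogen-bond donor of the (3,4-dichlorophenyl)amino group and brings in a six-membered non-aromatic ring. Among the measured compounds shown here, the single measured step, which swapped one aromatic ring for another and stayed within the scatter, does not speak directly to such a change, so the step of a 1.3-fold higher number from compound 2 to compound 3 (0.10 log units; within the scatter) is expected to lie within the scatter too, with no direction favoured. On that basis compound 3 is estimated to show 45 mL/min/kg in this assay, with a range from 18 mL/min/kg to 110 mL/min/kg.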

Compound 3, clearance: 42 mL/min/kg
The estimate for compound 3 lay 1.1-fold (0.03 log units) above the measured number, and the stated range covers the measured number.
By their numbers in this assay, from the lowest: compounds 2, 3 and 1 (each within the scatter of the next).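

In this assay, the earlier step had only set one aromatic ring against another on the amide-type nitrogen, whereas the two new steps replace the whole anilide-type group with piperidin-1-yl: a 1.2-fold higher number from compound 2 to compound 3 (0.07 log units; within the scatter) and a 1.4-fold lower number from compound 1 to compound 3 (0.15 log units; within the scatter) are the readings for that replacement. Both steps lie within the scatter, so at this carbonyl carbon the compounds shown give no sign of a measurable difference between a non-aromatic ring without the amide hydrogen and either of the two substituted phenylamino groups. The material at hand contains nothing that bears on what lies behind these numbers.

The compounds shown leave open whether any group on this carbonyl carbon would give a step beyond the scatter, for example morpholin-4-yl, dimethylamino or a longer open chain ending in an amine. They also leave open whether the same replacement would read alike if the rest of the shared core were altered, since the core stays the same in all three compounds.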